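Series notes: aryl swap on the ring nitrogen

The source may report more compounds than this note shows. Statements on the series, on what has been measured and on what is new or still open speak of the compounds shown alone.

The series shares one core, carried here by compound 1 `CCOC(=O)C1=C(C)N/C(=C/c2cc(C)n(-c3ccc(Cl)cc3)c2C)C1=O` and compound 2 `CCOC(=O)C1=C(C)N/C(=C/c2cc(C)n(-c3cc(OC)c(OC)c(OO)c3)c2C)C1=O`. In a physicochemical assay for lipophilicity, read by HPLC, at pH 7.4 (a higher number here means a more lipophilic compound, a lower number a more polar compound), compound 1 gives 3.4, and in this assay compound 2 gives 2.6. Of the two numbers, compound 1 stands highest; the nearest is compound 2, which lies lower by a gap that is beyond the scatter. For the measured compounds named here, only these two numbers are known, and no single-point step between them has been worked out, so they show no more than that the two aryl groups on the ring nitrogen give clearly different values.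

Compound 3 `CCOC(=O)C1=C(C)N/C(=C/c2cc(C)n(-c3ccncc3)c2C)C1=O` is the next member and is still to be measured in this assay. It differs from compound 1 in one place: pyridin-4-yl in place of 4-chlorophenyl on an aromatic nitrogen. For the step from compound 1 to compound 3 a fall in this assay is expected, of a size well beyond the scatter and larger than the gap between compound 1 and compound 2. On that basis compound 3 is estimated at 1.5 in this assay, with a range from 0.9 to 2.2, which means an expected step of a number 1.90 log units lower from compound 1 to compound 3 (beyond the scatter).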

Compound 3, distribution coefficient: 3.2
Compound 3: the middle estimate sits 1.70 log units below what was measured; measured number above the stated range.
By their numbers in this assay, from the lowest: compound 2; then compounds 3 and 1 (each within the scatter of the next).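

For the compounds shown here, the step on the aromatic nitrogen of the five-membered ring is the first single-place comparison: in this assay, the change gives a number 0.20 log units lower from compound 1 to compound 3 (within the scatter), so pyridin-4-yl and 4-chlorophenyl cannot be told apart at this position by this read-out. This holds although the exchange removes the chlorine, puts a ring nitrogen into the six-membered aromatic ring and brings in a hydrogen-bond acceptor that the leaving group lacks, so at this position neither that acceptor nor the loss of chlorine moves the number beyond the scatter in this one pair. Going by these compounds alone, nothing at hand accounts for this result, and the single pair gives no ground for a reason.

Still open, as far as these compounds go, is whether a pyridine ring joined through another ring carbon, or a phenyl ring carrying a carboxylic acid or an amine, would stay as close to compound 1 in this assay. Within the data shown here, also open is whether the same exchange gives a step this small on a core that differs elsewhere, since only one such pair is at hand.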